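Notes on a fluorine swap in the series

The source may report more compounds than this note shows. Statements on the series, on what has been measured and on what is new or still open speak of the compounds shown alone.

- compound 1 `CC(O)(CSc1ccc(S(F)(F)(F)(F)F)cc1)C(=O)Nc1cccc(S(F)(F)(F)(F)F)c1` gives 24800 nM in a functional assay on DU-145 cells (Homo sapiens) for antiproliferative activity, read by propidium iodide staining, with a stated time of 96 h; a lower number here means a stronger inhibitor, a higher number a weaker inhibitor
- compound 2 `CC(O)(CS(=O)(=O)c1ccc(S(F)(F)(F)(F)F)cc1)C(=O)Nc1cccc(S(F)(F)(F)(F)F)c1` gives 17400 nM in this assay

Compound 2, at 17400 nM in this assay, stands within the scatter of compound 1, so these two values do not separate. Compound 3 `CC(O)(CS(=O)(=O)c1ccc(F)cc1)C(=O)Nc1cccc(S(F)(F)(F)(F)F)c1` differs from compound 2 in one place (one fluorine atom in place of a group of 6 heavy atoms (5 fluorine, 1 sulfur; no ring), on an aromatic carbon): one fluorine atom in place of a group of 6 heavy atoms (5 fluorine, 1 sulfur; no ring), on an aromatic carbon, para to a large group. Within the data shown here, no measured pair shows this change, so the expectation is loose. A small step toward a higher number in this assay is expected, within the scatter, and the estimated step is a 1.7-fold higher number from compound 2 to compound 3 (0.24 log units; within the scatter) in this reading. Compound 3 is estimated at 30000 nM (expected range 12000 nM to 70000 nM).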

Compound 3, half-maximal inhibitory concentration: 48800 nM
Beside the measured number, compound 3's estimate is 1.6-fold (0.21 log units) below it; measured number inside the range.
By their numbers in this assay, from the lowest: compounds 2, 1 and 3 (each within the scatter of the next, the first and the last beyond it).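

Replacing the group of 6 heavy atoms (5 fluorine, 1 sulfur; no ring) with one fluorine atom, on an aromatic carbon para to a large group, gives a 2.8-fold higher number from compound 2 to compound 3 (0.45 log units; beyond the scatter) in this assay. This position therefore responds to the change, with the fluorine compound 3 the weaker inhibitor, although the step is modest and rests on this single pair. No measurement available here accounts for the step.

As far as these compounds go, whether the number follows the heavy-atom count of the group remains open, and a chlorine atom, a trifluoromethyl group or a methoxy group on the same carbon would test that. From the compounds shown here alone, whether the same swap gives a comparable step on the core of compound 1 also remains open.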